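The source may report more compounds than this note shows. Statements on the series, on what has been measured and on what is new or still open speak of the compounds shown alone.

In a functional assay on NCI-H23 cells (Homo sapiens) for antiproliferative activity, read by sulforhodamine B assay (a lower number here means a stronger inhibitor of growth, a higher number a weaker inhibitor of growth), compound 3 `CC(C)=CCOc1cccc(O)c1C(=O)/C=C/c1ccc(O)cc1` gives only a limit, > 30000 nM. Compound 1 `CCCCCCOc1cccc(O)c1C(=O)/C=C/c1ccc(O)cc1` likewise gives only a limit, > 30000 nM. Compound 2 `CC(C)(C)CCOc1cccc(O)c1C(=O)/C=C/c1ccc(O)cc1` gives a measured number, 3130 nM. Compound 4 `O=C(/C=C/c1ccc(O)cc1)c1c(O)cccc1OCC1CCCCC1` differs from compound 3 by cyclohexyl in place of 2-methylprop-1-en-1-yl on a saturated chain carbon bound to an oxygen on an aromatic ring, so that cyclohexylmethoxy stands in place of (3-methylbut-2-en-1-yl)oxy. Among the compounds with values here, two measured steps bear on this change: an at least 9.5-fold lower number from compound 1 to compound 2 (0.98 log units; beyond the scatter), and an at least 9.5-fold higher number from compound 2 to compound 3 (0.98 log units; beyond the scatter). The third, a step that the two limits leave unreadable from compound 1 to compound 3, offers no guidance. Within these three compounds, the read-out moves with the end of the chain. Compound 4 shares a branched saturated chain end with compound 2, at 3130 nM, and a lower number than for compound 3 is therefore expected. Compound 1 also lacks a double bond outside aromatic rings and still gives only a limit, so the lack of that double bond is not enough. Compound 4 may yet fall at the limit of > 30000 nM in this assay, at which 2 of the 3 values shown sit. The estimated change is an at least 3.7-fold lower number from compound 3 to compound 4 (0.57 log units; beyond the scatter), of modest size. The expected value for compound 4 is 8000 nM, with an estimated range from 2000 nM to 30000 nM.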

Compound 4, concentration for 50% growth inhibition: > 30000 nM
Compound 4: only a limit was reported; the forecaster's own chance of this, stated with the estimate: 35%; middle value at least 3.7-fold (0.57 log units) from the limit.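

In this assay compound 4 gives only a limit, > 30000 nM. Cyclohexyl in place of neopentyl at this position gives an at least 9.5-fold higher number from compound 2 to compound 4 (0.98 log units; beyond the scatter), so a branched saturated chain end is not enough on its own, and among the compounds shown only compound 2 gives a measured number. The steps from compound 3 and from compound 1 to compound 4 cannot be read, and the series now gathers at one point: the limit of > 30000 nM in this assay, at which 3 of the 4 values shown sit.

The compounds shown leave open whether a 2-cyclohexylethyl group, or a longer chain ending in tert-butyl, would also give a measured number in this assay. As far as these compounds go, how far compound 1, compound 3 and compound 4 lie from one another beyond that limit also remains unknown.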